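Urea versus amide at the anilide end of a pyrazole series

A few compounds are considered here, and "the series" means these few. Any claim that something is new, unique, unknown or untested is made for them only; others in the source may bear on it.

Measured so far:
Compound 1, `COc1cc(-c2nn(-c3cccc(NC(=O)Nc4cc(C(F)(F)F)cc(C(F)(F)F)c4)c3)cc2-c2ccncc2)ccc1Cl`: 3180 nM in a functional assay on U-251 cells (Homo sapiens) for inhibition, read by sulforhodamine B assay, with a stated time of 48 h; on this read-out lower numbers stand for higher toxicity in this test and higher numbers for lower toxicity in this test
Compound 2, `COc1cc(-c2nn(-c3cccc(NC(=O)c4cccc(C(F)(F)F)c4)c3)cc2-c2ccncc2)ccc1Cl`: > 50000 nM in this assay

Compound 2 sits at a limit of this assay rather than at a number, marked by the limit of > 50000 nM in this assay, at which 1 of the 2 values shown sits. Compound 3, `COc1cc(-c2nn(-c3cccc(NC(=O)Nc4ccc(Cl)c(Cl)c4)c3)cc2-c2ccncc2)ccc1Cl`, has not yet been tested. It differs from compound 2 by one change: (3,4-dichlorophenyl)amino in place of 3-(trifluoromethyl)phenyl on a carbonyl carbon. Compound 1 carries a related urea and gives 3180 nM, so compound 3 is expected to move toward higher toxicity in this assay, with a step of about an at least 10-fold lower number from compound 2 to compound 3 (1.00 log units; beyond the scatter). The estimate for compound 3 is 5000 nM, expected to lie between 1500 nM and 25000 nM.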

Compound 3, concentration lethal to 50% of the cells: > 50000 nM
Compound 3 gave a limit, no number (the forecaster's own chance of this, stated with the estimate: 20%); middle value at least 10-fold (1.00 log units) from the limit.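

Compound 2 and compound 3 both sit at a limit rather than at a number, so no step between them can be read: the limit of > 50000 nM in this assay, at which 2 of the 3 values shown sit.

On these data alone, it stays open how far beyond that limit each compound lies, and so whether this change alters toxicity at all.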